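Triazole substituent: tert-butyl to 4-methylphenyl

A few compounds are considered here, and "the series" means these few. Any claim that something is new, unique, unknown or untested is made for them only; others in the source may bear on it.

Compound 3 `CC(C)(C)c1cn(C[C@H](O)[C@H]2OC(=O)C(OCc3ccccc3)=C2OCc2ccccc2)nn1` holds the lowest number of the three measured in a functional assay on MCF7 cells (Homo sapiens) for antiproliferative activity, read by MTT assay, with a stated time of 72 h (a lower number here means a stronger inhibitor, a higher number a weaker inhibitor), giving 730 nM. Compound 1 `O=C1O[C@H]([C@@H](O)Cn2cc(-c3ccc(Br)cc3)nn2)C(OCc2ccccc2)=C1OCc1ccccc1` gives 5620 nM and compound 2 `O=C1O[C@H]([C@@H](O)Cn2cc(-c3cccc(O)c3)nn2)C(OCc2ccccc2)=C1OCc1ccccc1` gives 51800 nM. The steps of a 7.7-fold lower number from compound 1 to compound 3 (0.89 log units; beyond the scatter) and a 71-fold lower number from compound 2 to compound 3 (1.85 log units; beyond the scatter) both run toward tert-butyl, while a 9.2-fold higher number from compound 1 to compound 2 (0.96 log units; beyond the scatter) separates the two aryl groups from each other. Compound 4 `Cc1ccc(-c2cn(C[C@H](O)[C@H]3OC(=O)C(OCc4ccccc4)=C3OCc3ccccc3)nn2)cc1` goes the other way: 4-methylphenyl in place of tert-butyl on an aromatic carbon. Both aryl-bearing analogues sit well above compound 3 in this assay, and the nearer comparison for a 4-methylphenyl group is compound 1 with 5620 nM rather than compound 2. A rise of moderate size is therefore expected, a 5.5-fold higher number from compound 3 to compound 4 (0.74 log units; beyond the scatter). Compound 4 is estimated at 4000 nM, with a range of 1000 nM to 16000 nM.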

Compound 4, half-maximal inhibitory concentration: > 100000 nM
Compound 4 was reported as a limit (the forecaster's own chance of this, stated with the estimate: 5%); middle value at least 25-fold (1.39 log units) away from the limit.
By their numbers in this assay, from the lowest: compound 3; then compound 1; then compound 2. At a limit, above all of these: compound 4.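

In this assay compound 4 stands only as a limit of the assay, not as a number: the limit of > 100000 nM in this assay, at which 1 of the 4 values shown sits. Among these compounds, replacing tert-butyl with 4-methylphenyl costs far more than the aryl groups of the earlier compounds suggested, an at least 130-fold higher number from compound 3 to compound 4 (2.13 log units; beyond the scatter), and the methyl-for-bromo change alone gives an at least 17-fold higher number from compound 1 to compound 4 (1.25 log units; beyond the scatter), so the substituent on the aryl ring matters here as well as the aryl ring itself. Among the compounds shown here, by contrast, an at least 1.9-fold higher number from compound 2 to compound 4 (0.28 log units; that floor lies within the scatter) is only a floor and sets no order for that pair.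

As far as these compounds go, it remains open whether unsubstituted phenyl or 4-aminophenyl follows the bromo or the methyl analogue. Whether cyclohexyl keeps the level of tert-butyl is also unresolved.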